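A Shorter Side Chain on a Shared Core

The compounds below may be only part of what the source reports. "The series", "measured", "known", "first", "only" and "open" are said of these compounds alone.

Compound 1, `CCCOC(=O)Nc1ccc([Se]C#N)cc1`: 9100 nM
Compound 2, `N#C[Se]c1ccc(NC(=O)Oc2ccc(F)cc2)cc1`: 29500 nM
Compound 3, `N#C[Se]c1ccc(NC(=O)OCc2ccc([N+](=O)[O-])cc2)cc1`: 18000 nM

Of the compounds shown here, three on a shared core have been measured in an ADME assay on 184B5 cells (Homo sapiens) for cytotoxicity, read by MTT assay, with a stated time of 72 h; on this read-out higher numbers stand for weaker inhibition of growth and lower numbers for stronger inhibition of growth. Compound 1 gives 9100 nM, the lowest of the three numbers. Compound 3, with 18000 nM, comes nearest to it and sits within the scatter, so the two cannot be ranked against each other. Compound 2, with 29500 nM, lies furthest from compound 1, and that gap is beyond the scatter.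

The unmeasured compound 4, `CCOC(=O)Nc1ccc([Se]C#N)cc1`, differs from compound 1 in one place: hydrogen in place of methyl on a saturated chain carbon, two bonds along the chain from an oxygen next to a carbonyl group. Cut one bond further out, the same difference reads propyl to ethyl, or propoxy to ethoxy. For the measured compounds named here, no step between two measured compounds tells how this kind of change behaves on this core; the measured pairs all differ in more than one place. With nothing to set against it, the change is expected to be small, in no particular direction, and to stay within the scatter of compound 1.

Compound 4 is therefore expected to give about 10000 nM in this assay, with a range from 4500 nM to 25000 nM. That estimate means a step from compound 1 to compound 4 of a 1.1-fold higher number from compound 1 to compound 4 (0.04 log units; within the scatter), which is not expected to exceed the scatter.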

Compound 4, concentration for total growth inhibition: 18600 nM
For compound 4 the middle estimate is 1.9-fold (0.27 log units) below the measured one; low and high end bracket the measured number.
By their numbers in this assay, from the lowest: compounds 1, 3, 4 and 2 (each within the scatter of the next, the first and the last beyond it).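

For the compounds shown here, the step from propyl to ethyl gives the first reading of this position on the shared core: in this assay the loss of the methyl, on a saturated chain carbon, two bonds along the chain from an oxygen next to a carbonyl group, comes to a 2.0-fold higher number from compound 1 to compound 4 (0.31 log units; beyond the scatter) and so means weaker inhibition of growth. The step is modest but lies beyond the scatter, which shows that even this one carbon at the end of the chain registers on this read-out, and that on this core the shorter chain does not simply match the propyl chain. Nothing at hand explains why the number moves in this direction.

From the compounds shown here alone, a single step at a single position gives a direction for this one change only, so it remains open whether a longer chain such as butyl would lower the number further or whether the trend stops at propyl. Also open, going by these compounds, are how a branched chain such as isopropyl, or a chain ending in an amine or a hydroxyl group, would behave at this place.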